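This account rests on a few compounds, and the source may have more. Where it says the series, first, only, none or still open, it means among the compounds named here.

Working notes on the series. The shared core of compound 1 `Clc1ccccc1-c1ccc2[nH]ncc2c1` carries a chloro group on an aromatic carbon; in an assay on CHO-TREX cells for antagonist activity at transient receptor potential cation channel subfamily A member 1 (Homo sapiens), read by FLIPR and calcium flux, with a stated time of 10 min (on this read-out lower numbers stand for stronger inhibition and higher numbers for weaker inhibition), compound 1 gives 1230 nM. Two measured analogues replace that chloro with a carbon chain: compound 2 `CCc1ccccc1-c1ccc2[nH]ncc2c1` gives 584 nM, and compound 3 `CC(C)c1ccccc1-c1ccc2[nH]ncc2c1` gives 514 nM. Compound 1 thus stands with the highest number of the three, its nearest neighbour being compound 2 and its furthest compound 3.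

The next compound, compound 4 `CC(C)(C)c1ccccc1-c1ccc2[nH]ncc2c1`, is not yet measured. It differs from compound 1 as follows: tert-butyl in place of chloro on an aromatic carbon.

Going by the values given here, the steps that bear on this change are the two replacements of chloro by a chain already measured: a 2.1-fold lower number from compound 1 to compound 2 (0.32 log units; beyond the scatter) and a 2.4-fold lower number from compound 1 to compound 3 (0.38 log units; beyond the scatter). Going from ethyl to isopropyl adds little: a 1.1-fold lower number from compound 2 to compound 3 (0.06 log units; within the scatter). Both chain replacements lowered the number by a modest but real amount, and the added methyl on the chain made no difference beyond the scatter. The step to tert-butyl is therefore expected to lower the number as well, by a modest amount in the same direction, with no basis in the measured steps for a larger change.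

For compound 4 in this assay the expected value is 470 nM, with a range from 200 nM to 1100 nM, which means an expected step of a 2.6-fold lower number from compound 1 to compound 4 (0.42 log units; beyond the scatter).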

Compound 4, half-maximal inhibitory concentration: 3400 nM
Estimate against measurement, compound 4: 7.2-fold (0.86 log units) below; measured number above the stated range.
By their numbers in this assay, from the lowest: compounds 3 and 2 (each within the scatter of the next); then compound 1; then compound 4.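

In this assay, replacing chloro with a carbon group on this aromatic carbon, ortho to a group of 9 heavy atoms, does not always lower the number: tert-butyl gives a 2.8-fold higher number from compound 1 to compound 4 (0.44 log units; beyond the scatter) and so reverses the direction seen with ethyl and isopropyl. The reversal comes with the last added methyl, which gives a 6.6-fold higher number from compound 3 to compound 4 (0.82 log units; beyond the scatter) and contrasts with the earlier added methyl, whose step from ethyl to isopropyl stayed within the scatter, so branching on this chain does not act evenly. Measured directly against ethyl, tert-butyl gives a 5.8-fold higher number from compound 2 to compound 4 (0.77 log units; beyond the scatter) and thereby leaves ethyl and isopropyl with lower numbers than both chloro and tert-butyl.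

No evidence is available to explain this reversal. The compounds shown leave open whether a cyclopropyl ring, a methoxy group or a longer straight chain at this position would fall with ethyl and isopropyl or with tert-butyl.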